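Isobutyl sulfone replaces hydroxypyrrolidine sulfonamide

The source may report more compounds than this note shows. Statements on the series, on what has been measured and on what is new or still open speak of the compounds shown alone.

Measured compounds:
compound 1 `O=C([C@@H]1CCCN(S(=O)(=O)c2ccc(S(=O)(=O)C3CC3)cc2)C1)N1CCC(F)(F)CC1`, 129 nM
compound 2 `CN(C)S(=O)(=O)c1ccc(S(=O)(=O)N2CCC[C@@H](C(=O)N3CCC(F)(F)CC3)C2)cc1`, 560 nM
compound 3 `O=C([C@@H]1CCCN(S(=O)(=O)c2ccc(S(=O)(=O)N3CC[C@H](O)C3)cc2)C1)N1CCC(F)(F)CC1`, 580 nM

Three compounds share a core and differ only in the group on the outer sulfonyl sulfur. In a functional assay on BXPC-3 cells (Homo sapiens) for inhibition, read by MTT assay, with a stated time of 7 days (a higher number here means a weaker inhibitor, a lower number a stronger inhibitor), compound 1 gives 129 nM, compound 2 gives 560 nM and compound 3 gives 580 nM. Compound 3 thus has the highest number of the three, but its value and that of compound 2 lie within the scatter of each other, as shown by a 1.0-fold higher number from compound 2 to compound 3 (0.02 log units; within the scatter); only compound 1 stands apart, with a 4.5-fold higher number from compound 1 to compound 3 (0.65 log units; beyond the scatter).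

Compound 4 `CC(C)CS(=O)(=O)c1ccc(S(=O)(=O)N2CCC[C@@H](C(=O)N3CCC(F)(F)CC3)C2)cc1` is not yet measured. The change from compound 3 is isobutyl in place of 3-hydroxypyrrolidin-1-yl on a sulfonyl sulfur. Going by the values given here, the steps that bear on this are a 4.5-fold higher number from compound 1 to compound 3 (0.65 log units; beyond the scatter) and a 4.3-fold higher number from compound 1 to compound 2 (0.64 log units; beyond the scatter): both times a carbon-only group on that sulfur gave a lower number than a nitrogen-linked group. Isobutyl is again a carbon-only group, though not cyclopropyl, so no measured step covers it exactly. A step back toward the number of compound 1 is therefore expected, of size a 3.2-fold lower number from compound 3 to compound 4 (0.51 log units; beyond the scatter) in this assay. Compound 4 is estimated at 180 nM, with a range from 70 nM to 450 nM.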

Compound 4, half-maximal inhibitory concentration: 311 nM
Estimate against measurement, compound 4: 1.7-fold (0.24 log units) below; measured number inside the range.
By their numbers in this assay, from the lowest: compound 1; then compounds 4, 2 and 3 (each within the scatter of the next).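

In this assay, the isobutyl group of compound 4 does not separate from the nitrogen-linked groups, with a 1.9-fold lower number from compound 3 to compound 4 (0.27 log units; within the scatter) and a 1.8-fold lower number from compound 2 to compound 4 (0.26 log units; within the scatter); both steps stay small even though the first exchanges a 3-hydroxypyrrolidin-1-yl group, with its ring, hydrogen-bond donor and defined stereocentre, for an open carbon chain with none of these. The earlier suggestion that a carbon-only group on this sulfonyl sulfur gives a lower number than a nitrogen-linked group therefore does not hold across the set, and compound 4 is the compound that goes against it. Cyclopropyl remains apart from isobutyl, with a 2.4-fold higher number from compound 1 to compound 4 (0.38 log units; beyond the scatter), so among the four compounds the lower number belongs to compound 1 alone and not to carbon-only groups as a class.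

As far as these compounds go, whether the separation follows the ring of cyclopropyl remains open, since a cyclobutyl, isopropyl or methyl group on the same sulfonyl sulfur could fall with either compound 1 or compound 4. Nothing given here explains why cyclopropyl differs from isobutyl at this position.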